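The compounds below may be only part of what the source reports. "The series", "measured", "known", "first", "only" and "open" are said of these compounds alone.

Working notes on the series. Compound 1 `CC1(C)CCN(c2ccc(C(=O)NS(=O)(=O)c3ccc(NC(C)(C)CSc4ccccc4)c([N+](=O)[O-])c3)cc2)CC1` and compound 2 `CCCCCC1(OC)CCN(c2ccc(C(=O)NS(=O)(=O)c3ccc(N[C@H](CCN(C)C)CSc4ccccc4)c([N+](=O)[O-])c3)cc2)CC1` share a core and have both been run in a functional assay (FL5.12 cells, Mus musculus) with Apoptosis regulator Bcl-2 (Homo sapiens) as the target; on this read-out higher numbers stand for an effect only at larger amounts of compound and lower numbers for an effect already at smaller amounts. Compound 1 gives 2200 nM. Compound 2 gives 3000 nM, the highest of the two numbers, though its gap to compound 1 lies within the scatter, so the two compounds are not separated on this read-out. Among the measured compounds shown here, no step between measured compounds that differ in one place is available. Compound 3 `COC1(Cc2cccc(Cl)c2)CCN(c2ccc(C(=O)NS(=O)(=O)c3ccc(N[C@H](CCN(C)C)CSc4ccccc4)c([N+](=O)[O-])c3)cc2)CC1` remains to be measured; it differs from compound 2 in one place: 3-chlorophenyl in place of butyl on a saturated chain carbon bound to a saturated ring carbon. For the measured compounds named here, with no comparable step in the measured pairs, the direction of the change is open; a modest step in this assay from compound 2 to compound 3 of a 2.0-fold lower number from compound 2 to compound 3 (0.30 log units; within the scatter) toward lower numbers is expected, at the edge of the scatter. For compound 3 a value of 1500 nM is estimated, with a range from 400 nM to 6000 nM.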

Compound 3, half-maximal effective concentration: 300 nM
Estimate against measurement, compound 3: 5.0-fold (0.70 log units) above, outside the stated range (below it).
By their numbers in this assay, from the lowest: compound 3; then compounds 1 and 2 (each within the scatter of the next).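

In this assay, 3-chlorophenyl in place of butyl on a saturated chain carbon bound to a saturated ring carbon gives a 10-fold lower number from compound 2 to compound 3 (1.00 log units; beyond the scatter), a step beyond the scatter. This position therefore responds to the group it carries, which the earlier pair, differing in more than one place, could not show. No measurement on hand accounts for the step.

The compounds shown leave open whether the step goes with the aromatic ring or with the chlorine, a question that a plain benzyl at this position would bear on directly. Also open, from the compounds shown here alone, is how a longer chain or an amine would read here, and so whether the change seen is specific to 3-chlorobenzyl.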